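The source may hold more compounds than are shown below. What is called first, only, known or untested is meant among the compounds shown, and "the series" means these compounds.

Three compounds of the series have been run in an in vitro ADME assay on microsomes from liver (Homo sapiens) for pharmacokinetics, read by LC-MS, with a stated time of 10 min, tested at 1 uM; on this read-out lower numbers stand for slow clearance and higher numbers for fast clearance. Compound 1 `CN1C[C@H](C(=O)Nc2ccc(Cl)c(Cl)c2)[C@@H](c2ccc(/C=C/C(=O)Nc3ccccc3N)cc2)C1` gives 14 mL/min/kg, compound 2 `CN1C[C@H](C(=O)Nc2ccc(Cl)cc2F)[C@@H](c2ccc(/C=C/C(=O)Nc3ccccc3N)cc2)C1` gives 11 mL/min/kg, and compound 3 `CCN1C[C@H](C(=O)Nc2ccc(Cl)cc2)[C@@H](c2ccc(/C=C/C(=O)Nc3ccccc3N)cc2)C1` gives 12 mL/min/kg. Within the data shown here, the single one-point step, a 1.3-fold lower number from compound 1 to compound 2 (0.10 log units; within the scatter), alters only the aryl amide. On the numbers shown compound 3 stands second highest of three, but its gaps to compound 2 and to compound 1 are both within the scatter, so the three values read as one cluster. Compound 4 `Nc1ccccc1NC(=O)/C=C/c1ccc([C@H]2CN(Cc3ccccc3)C[C@@H]2C(=O)Nc2ccc(Cl)cc2)cc1` differs from compound 3 by phenyl in place of methyl on a saturated chain carbon bound to an amine nitrogen in a ring. Among the measured compounds shown here, no measured step touches this position, and the step of a 1.3-fold lower number from compound 1 to compound 2 (0.10 log units; within the scatter) gives no guide to it. Compound 4 is accordingly estimated close to the cluster, with a wide range, at 20 mL/min/kg (10 mL/min/kg to 40 mL/min/kg), the expected step being a 1.7-fold higher number from compound 3 to compound 4 (0.22 log units; within the scatter).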

Compound 4, clearance: 3 mL/min/kg
For compound 4 the middle estimate is 6.7-fold (0.82 log units) above the measured one; measured number below the stated range.
By their numbers in this assay, from the lowest: compound 4; then compounds 2, 3 and 1 (each within the scatter of the next).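

In this assay, phenyl in place of methyl on a saturated chain carbon bound to an amine nitrogen in a ring gives a 4.0-fold lower number from compound 3 to compound 4 (0.60 log units; beyond the scatter) and is the only step shown that lies beyond the scatter. This position can therefore move the read-out, whereas the aryl amide change gives only a 1.3-fold lower number from compound 1 to compound 2 (0.10 log units; within the scatter). Nothing measured here bears on the reason for this step. As far as these compounds go, whether the aromatic ring itself is needed remains open, since a propyl chain, a cyclohexylmethyl group or a pyridylmethyl group at this position could separate ring from chain.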